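The source may hold more compounds than are shown below. What is called first, only, known or untested is meant among the compounds shown, and "the series" means these compounds.

Measured in a functional assay on HT-29 cells (Homo sapiens) for cytotoxicity, read by MTT assay, with a stated time of 6 days (on this read-out lower numbers stand for an effect already at smaller amounts and higher numbers for an effect only at larger amounts of compound), each entry a limit of the assay and not a number:

Compound 1 `COC(=O)c1c(-c2ccc(OC)cc2)oc2ccccc2c1=O`: > 25 ug/mL
Compound 2 `COC(=O)c1c(-c2ccc([N+](=O)[O-])cc2)oc2ccccc2c1=O`: > 25 ug/mL
Compound 3 `COC(=O)c1c(-c2ccc([N+](=O)[O-])cc2)oc2cc(OC)ccc2c1=O`: > 25 ug/mL

Compound 3 has only a limit, > 25 ug/mL. The whole series sits at the limit of > 25 ug/mL in this assay, at which 3 of the 3 values shown sit.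

Compound 4 `COC(=O)c1c(-c2ccc(O)cc2)oc2cc(OC)ccc2c1=O` carries hydroxy in place of nitro on an aromatic carbon, para to a large group: hydroxy in place of nitro on an aromatic carbon. The nearest measured change, at the same place, is a step that the two limits leave unreadable from compound 1 to compound 2. The other measured change, a step that the two limits leave unreadable from compound 2 to compound 3, lies elsewhere. Within the data shown here, neither gives a size to carry over, so no step of known size or direction can be expected in this assay, and another limit is the likeliest result. Compound 4 is expected near 25 ug/mL, with an estimated range of 8 ug/mL to 60 ug/mL.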

Compound 4, concentration for half-maximal effect: 19.2 ug/mL
The estimate for compound 4 lay 1.3-fold (0.11 log units) above the measured number; the measured number falls inside the stated range.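

In this assay, hydroxy in place of nitro on an aromatic carbon, para to a large group, yields a number and not a limit, with an at least 1.3-fold lower number from compound 3 to compound 4 (0.11 log units; that floor lies within the scatter). Compound 3 has only a limit of the assay, > 25 ug/mL. The earlier steps cannot be read, and compound 4 alone leaves that limit: the limit of > 25 ug/mL in this assay, at which 3 of the 4 values shown sit.

From the compounds shown here alone, whether an amine or a carboxylic acid at this place would also give a number stays open. So does whether hydroxy gives one without the methoxy that compound 4 carries on the other side of the shared core.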